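The source may report more compounds than this note shows. Statements on the series, on what has been measured and on what is new or still open speak of the compounds shown alone.

Compound 1 `Cc1cc(C(=O)Nc2ccc(N3CC[C@H](N4CCC[C@@H]4C)C3)cc2C)on1` gives 1.1 nM in an assay on CHO cells for displacement of a labelled ligand from histamine receptor H3 (Macaca mulatta), read by scintillation counting, with a stated time of 1 h; a lower number here means a stronger inhibitor, a higher number a weaker inhibitor. Compound 2 `Cc1nc(C(=O)Nc2ccc(N3CC[C@H](N4CCC[C@@H]4C)C3)cc2C)co1` gives 4.6 nM in this assay, and the step of a 4.2-fold higher number from compound 1 to compound 2 (0.62 log units; beyond the scatter) is the only one measured so far; compound 2 therefore holds the higher of the two numbers, and stands beyond the scatter from compound 1.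

Compound 3 `Cc1cccc(C(=O)Nc2ccc(N3CC[C@H](N4CCC[C@@H]4C)C3)cc2C)n1` carries the change (6-methylpyridin-2-yl in place of 2-methyl-1,3-oxazol-4-yl on a carbonyl carbon). Going by the values given here, the one step that bears on it is the exchange of the ring on the carbonyl carbon from compound 1 to compound 2, which came out modest at a 4.2-fold higher number from compound 1 to compound 2 (0.62 log units; beyond the scatter); the new ring is a six-membered one with a single hetero atom rather than a five-membered one with two, so the single measured step gives only a rough scale. An aryl amide of this kind is expected to stay close to the two measured numbers, with a step of a 1.8-fold lower number from compound 2 to compound 3 (0.26 log units; within the scatter) anticipated, within the scatter. Compound 3 is thus expected to give 2.5 nM, in the range 0.8 nM to 8 nM.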

Compound 3, inhibition constant in the histamine receptor H3 assay: 1.4 nM
Beside the measured number, compound 3's estimate is 1.8-fold (0.25 log units) above it; the range from low to high includes it.
By their numbers in the histamine receptor H3 assay, from the lowest: compounds 1 and 3 (each within the scatter of the next); then compound 2.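

In the histamine receptor H3 assay compound 3 gives 1.4 nM and its six-membered 6-methylpyridin-2-yl ring on the carbonyl carbon separates from 2-methyl-1,3-oxazol-4-yl, with a 3.3-fold lower number from compound 2 to compound 3 (0.52 log units; beyond the scatter), yet it cannot be told apart from 3-methyl-1,2-oxazol-5-yl, with a 1.3-fold higher number from compound 1 to compound 3 (0.10 log units; within the scatter), so among these three rings the size of the ring does not by itself set the number, and 2-methyl-1,3-oxazol-4-yl alone stands apart. In a physicochemical assay for acid dissociation, compound 2 gives 10.1 and compound 3 gives 10.1 and the same exchange gives no change at the digits printed from compound 2 to compound 3 (within the scatter), so the acid dissociation constant does not follow the change seen in binding. Nothing measured here accounts for the difference between these rings.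

The compounds shown leave open whether the ring's methyl group matters at all, since every ring here carries one. As far as these compounds go, a plain phenyl ring, or a pyridine ring bearing an amine or a methoxy group in place of the methyl, remains untested in these data.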